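Spiro ketone series: aryl swap on the quinoline carboxamide

The compounds below may be only part of what the source reports. "The series", "measured", "known", "first", "only" and "open" are said of these compounds alone.

Measured compounds in a functional assay on A549 cells (Homo sapiens) for inhibition, read by MTT assay, with a stated time of 72 h; a higher number here means a weaker inhibitor, a lower number a stronger inhibitor:
Compound 1 `CC(C)(C)n1cc2c(n1)C(=O)CC1(CCN(C(=O)c3cc(-c4ccccc4Cl)nc4ccccc34)CC1)O2`: 2180 nM
Compound 2 `CC(C)(C)n1cc2c(n1)C(=O)CC1(CCN(C(=O)c3cc(-c4ccc(Br)cc4)nc4ccccc34)CC1)O2`: 9300 nM
Compound 3 `CN(C)c1ccc(-c2cc(C(=O)N3CCC4(CC3)CC(=O)c3nn(C(C)(C)C)cc3O4)c3ccccc3n2)cc1`: 1150 nM

Compound 2 gives the highest number of the three in this assay. Its nearest neighbour is compound 1, a 4.3-fold higher number from compound 1 to compound 2 (0.63 log units; beyond the scatter); the furthest is compound 3, an 8.1-fold lower number from compound 2 to compound 3 (0.91 log units; beyond the scatter). Both steps are beyond the scatter, so compound 2 reads as the weakest of the three on the present numbers.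

Compound 4 `CC(C)(C)n1cc2c(n1)C(=O)CC1(CCN(C(=O)c3cc(-c4ccccn4)nc4ccccc34)CC1)O2` is not yet measured. Relative to compound 2 the change is pyridin-2-yl in place of 4-bromophenyl on an aromatic carbon.

Among the measured compounds shown here, two measured steps bear on this. Leaving the 4-bromophenyl group for 2-chlorophenyl lowered the number, as seen in the reverse of a 4.3-fold higher number from compound 1 to compound 2 (0.63 log units; beyond the scatter); exchanging bromo for dimethylamino lowered it further, an 8.1-fold lower number from compound 2 to compound 3 (0.91 log units; beyond the scatter). Every departure from 4-bromophenyl so far has given a lower number, and pyridin-2-yl is a further departure. For the measured compounds named here, no measured step tells how a ring with one hetero atom behaves at this position, so the size is uncertain.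

The expectation for compound 4 is therefore a lower number than compound 2, in the region of the other two aryl variants: an estimated 3.1-fold lower number from compound 2 to compound 4 (0.49 log units; beyond the scatter).

Compound 4 is estimated at 3000 nM, with a range of 1000 nM to 10000 nM.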

Compound 4, half-maximal inhibitory concentration: 7720 nM
Compound 4: the middle estimate sits 2.6-fold (0.41 log units) below what was measured; low and high end bracket the measured number.
By their numbers in this assay, from the lowest: compounds 3 and 1 (each within the scatter of the next); then compounds 4 and 2 (each within the scatter of the next).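

In this assay, pyridin-2-yl and 4-bromophenyl at this position, next to the ring nitrogen, cannot be told apart (a 1.2-fold lower number from compound 2 to compound 4 (0.08 log units; within the scatter)). Leaving 4-bromophenyl therefore does not by itself bring the number down: compounds 1 and 3 fit that trend, compound 4 goes against it, and the six-membered ring with one hetero atom sits apart from both other aryl variants (a 6.7-fold higher number from compound 3 to compound 4 (0.83 log units; beyond the scatter); a 3.5-fold higher number from compound 1 to compound 4 (0.55 log units; beyond the scatter)). The position thus separates these aryl groups by more than the scatter, yet no evidence at hand accounts for that separation.

Still open, going by these compounds, is whether the ring nitrogen of compound 4 contributes anything, since a plain phenyl group would be the direct comparison for both pyridin-2-yl and 4-bromophenyl, while pyridin-3-yl and pyridin-4-yl would test where that nitrogen sits. Also open, on these data alone, is whether the low number of compound 3 is particular to dimethylamino, which 4-aminophenyl or 4-methoxyphenyl at the same position would help to settle.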